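The compounds below may be only part of what the source reports. "The series", "measured", "known", "first", "only" and "open" are said of these compounds alone.

Measured so far:
compound 1 `CC(=O)N1N=C(c2cc(O)c(O)c([N+](=O)[O-])c2)CC1c1ccc(C#N)cc1`: 48 nM
compound 2 `CC(=O)N1N=C(c2cc(O)c(O)c([N+](=O)[O-])c2)CC1c1ccoc1`: 180 nM

Both compounds share the same core and differ only in the group on the saturated ring carbon. In an assay for inhibition of Catechol O-methyltransferase (Rattus norvegicus), read by fluorescence and spectrophotometry (on this read-out lower numbers stand for stronger inhibition and higher numbers for weaker inhibition), compound 1 gives 48 nM, while compound 2 gives 180 nM. Going by the values given here, compound 2 therefore carries the higher of the two numbers, that is, the weaker inhibition; the only measured step, a 3.8-fold higher number from compound 1 to compound 2 (0.57 log units; beyond the scatter), replaces the 4-cyanophenyl group with furan-3-yl and lies beyond the scatter.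

Compound 3 `CC(=O)N1N=C(c2cc(O)c(O)c([N+](=O)[O-])c2)CC1c1cccc(O)c1` is the next step from compound 2: 3-hydroxyphenyl in place of furan-3-yl on a saturated ring carbon. Among the compounds with values here, the single measured step bears on this only loosely, since it shows that swapping one aromatic group for another on this carbon can shift the number by a modest amount, and that a six-membered carbon ring went with the lower number. The new group is again a six-membered carbon ring, so compound 3 is expected to move back toward the number of compound 1 rather than further away, with a 2.3-fold lower number from compound 2 to compound 3 (0.35 log units; beyond the scatter) as the expected size. The estimate for compound 3 in this assay is 80 nM, within a range from 30 nM to 250 nM.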

Compound 3, half-maximal inhibitory concentration: 75 nM
For compound 3 the middle estimate is 1.1-fold (0.03 log units) above the measured one, and the stated range covers the measured number.
By their numbers in this assay, from the lowest: compounds 1 and 3 (each within the scatter of the next); then compound 2.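

In this assay, the move away from furan-3-yl (a 2.4-fold lower number from compound 2 to compound 3 (0.38 log units; beyond the scatter)) shows that the earlier gap was not tied to the 4-cyanophenyl group alone, since a second six-membered aromatic ring of carbon only also sits apart from the five-membered ring, and no compound shown goes against this. The step between the two six-membered rings (a 1.6-fold higher number from compound 1 to compound 3 (0.19 log units; within the scatter)) lies within the scatter, so exchanging 4-cyanophenyl for 3-hydroxyphenyl on this saturated ring carbon gives no readable difference, even though the two groups carry different substituents at different points on the ring. No measurement shown explains why the numbers fall this way.

Going by these compounds alone, with only three groups in hand, ring size cannot be separated from the number of heavy atoms, because 3-hydroxyphenyl differs from furan-3-yl in both. On these data alone, it also remains open how this position would respond to an unsubstituted phenyl, a saturated cyclohexyl ring, or a phenyl ring bearing an amine or a carboxylic acid, so the limits of what the position tolerates are still unknown.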